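The source may hold more compounds than are shown below. What is called first, only, known or untested is meant among the compounds shown, and "the series" means these compounds.

Measured in a functional assay on A2780 cells (Homo sapiens) for antiproliferative activity, read by resazurin assay, with a stated time of 72 h; on this read-out higher numbers stand for weaker inhibition and lower numbers for stronger inhibition:
Compound 1 `CN(Cc1ccccc1)C(=O)c1cc2c(Cc3ccccc3)n[nH]c2cc1O`: 980 nM
Compound 2 `CN(C(=O)c1cc2c(Cc3ccccc3)n[nH]c2cc1O)c1ccco1`: 2500 nM
Compound 3 `CN(Cc1ccccc1Cl)C(=O)c1cc2c(Cc3ccccc3)n[nH]c2cc1O`: 1100 nM

The number for compound 3 cannot be separated from that of compound 1, with a 1.1-fold higher number from compound 1 to compound 3 (0.05 log units; within the scatter). The gap to the furan-2-yl amide, compound 2, is real but modest, with a 2.3-fold lower number from compound 2 to compound 3 (0.36 log units; beyond the scatter).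

Compound 4 `CN(Cc1cccc(F)c1)C(=O)c1cc2c(Cc3ccccc3)n[nH]c2cc1O` keeps the shared core and the amide and changes only the aromatic group: 3-fluorophenyl in place of 2-chlorophenyl on a saturated chain carbon bound to an amide-type nitrogen. In words, 3-fluorophenyl stands in place of 2-chlorophenyl on a saturated chain carbon bound to an amide-type nitrogen. The same difference can be read as 2-chlorobenzyl to 3-fluorobenzyl.

The measured step closest to this change is the one that put chloro in place of hydrogen on the aromatic carbon, a 1.1-fold higher number from compound 1 to compound 3 (0.05 log units; within the scatter), and it stayed within the scatter. For the measured compounds named here, the only steps beyond the scatter, a 2.6-fold higher number from compound 1 to compound 2 (0.41 log units; beyond the scatter) and a 2.3-fold lower number from compound 2 to compound 3 (0.36 log units; beyond the scatter), exchange the benzyl-type group for furan-2-yl or back, which compound 4 does not do. Going by the values given here, this is a single precedent, and no fluoro compound has been measured. Even so, no step beyond the scatter is expected in this assay, and the expected step is a 1.1-fold lower number from compound 3 to compound 4 (0.04 log units; within the scatter). For compound 4 the estimated value is 1000 nM, with an expected range from 550 nM to 1900 nM.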

Compound 4, half-maximal inhibitory concentration: 5000 nM
Compound 4: middle estimate off by 5.0-fold (0.70 log units), on the low side, and the stated range ends below it.
By their numbers in this assay, from the lowest: compounds 1 and 3 (each within the scatter of the next); then compounds 2 and 4 (each within the scatter of the next).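

In this assay the aromatic ring of the benzyl-type group proves to be a place where a small change can count: there is a 4.5-fold higher number from compound 3 to compound 4 (0.66 log units; beyond the scatter) and a 5.1-fold higher number from compound 1 to compound 4 (0.71 log units; beyond the scatter) even though the earlier chloro change had stayed within the scatter. A benzyl-type group on the amide-type nitrogen therefore does not by itself hold the number near that of compound 1, and with a 2.0-fold higher number from compound 2 to compound 4 (0.30 log units; within the scatter) the 3-fluorobenzyl amide cannot be told apart from the furan-2-yl amide in this read-out. Nothing measured in this account explains why the 3-fluorobenzyl group behaves differently from the 2-chlorobenzyl group.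

The step from 2-chlorophenyl to 3-fluorophenyl alters both the halogen and its place on the ring, so the compounds shown cannot say which of the two matters, and the 3-chlorobenzyl and 2-fluorobenzyl amides would be needed to separate them. As far as these compounds go, it also remains open how other groups on this ring, such as a methoxy or a nitrile, or an amine on the benzyl ring, would fare in this read-out.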